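The source may report more compounds than this note shows. Statements on the series, on what has been measured and on what is new or still open speak of the compounds shown alone.

Working notes on the aryl-imidazoline series.

Compound 1 `Cc1ncc(-c2ccccc2NCC2=NCCN2)o1` gives 110 nM in a functional assay for activation of Alpha-1A adrenergic receptor (Homo sapiens), read by calcium flux (a lower number here means that less compound is needed, a higher number that more compound is needed for the effect), the highest of the three numbers recorded. Compound 2 `c1csc(-c2ccccc2NCC2=NCCN2)c1` gives 2.24 nM and compound 3 `Cc1cc(-c2ccccc2NCC2=NCCN2)on1` gives 38.9 nM in this assay. The two measured steps from compound 1 both exchange the five-membered ring on the core: a 49-fold lower number from compound 1 to compound 2 (1.69 log units; beyond the scatter) and a 2.8-fold lower number from compound 1 to compound 3 (0.45 log units; beyond the scatter). Between the other two compounds, a 17-fold higher number from compound 2 to compound 3 (1.24 log units; beyond the scatter).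

Compound 4 `Cc1nc(-c2ccccc2NCC2=NCCN2)no1` is not yet measured. Relative to compound 1 the change is 5-methyl-1,2,4-oxadiazol-3-yl in place of 2-methyl-1,3-oxazol-5-yl on an aromatic carbon. Both prior exchanges of this ring lowered the number, but neither involved a ring with three hetero atoms, and the modest size of the step from compound 1 to compound 3 is the closer precedent. For compound 4 the expected step in this assay is a 1.4-fold higher number from compound 1 to compound 4 (0.13 log units; within the scatter), with no confident direction. The estimated value for compound 4 is 150 nM, within a range of 40 nM to 600 nM.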

Compound 4, half-maximal effective concentration: 724 nM
The estimate for compound 4 lay 4.8-fold (0.68 log units) below the measured number; measured number above the stated range.
By their numbers in this assay, from the lowest: compound 2; then compound 3; then compound 1; then compound 4.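

Placed on an aromatic carbon ortho to a group of 7 heavy atoms, the five-membered ring can also raise the number, with a 6.6-fold higher number from compound 1 to compound 4 (0.82 log units; beyond the scatter), whereas both earlier exchanges of the 2-methyl-1,3-oxazol-5-yl ring lowered it. For the compounds shown here, the position is more sensitive than the earlier compounds showed: a 19-fold higher number from compound 3 to compound 4 (1.27 log units; beyond the scatter) separates two methyl-bearing rings, and the spread across the series now reaches a 320-fold higher number from compound 2 to compound 4 (2.51 log units; beyond the scatter), with the ring of 3 hetero atoms giving the highest number of the four. No measurement available here bears on why the 5-methyl-1,2,4-oxadiazol-3-yl ring gives this result.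

On these data alone, whether the methyl group on this ring contributes to the number remains open, as does what a phenyl ring, or a ring carrying an amine or a carboxylic acid, would give at this position in this assay. As far as these compounds go, how these ring exchanges would read on any other core also remains open.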